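Methoxy count on the aryl ring: compound 3 pending

The compounds below may be only part of what the source reports. "The series", "measured", "known", "first", "only" and "open" are said of these compounds alone.

Measured so far:
Compound 1, `COc1ccc(-c2cc(/C=C/C(=O)c3ccc(N)cc3)[nH]n2)cc1`, in a functional assay on HCC 2998 cells (Homo sapiens) for inhibition, read by sulforhodamine B assay, with a stated time of 48 h (on this read-out lower numbers stand for higher toxicity in this test and higher numbers for lower toxicity in this test), gives 6170 nM.
Compound 2, `COc1cc(-c2cc(/C=C/C(=O)c3ccc(N)cc3)[nH]n2)cc(OC)c1OC`, in this assay gives 6530 nM.

Only two compounds carry numbers, and they sit within the usual scatter of each other, so compound 2 cannot be set apart from compound 1 on what is shown: both give a sulforhodamine B read-out in the same band, and the difference between three methoxy groups and one on the aryl ring of the shared core leaves no visible trace in this assay.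

Compound 3, `COc1ccc(-c2cc(/C=C/C(=O)c3ccc(N)cc3)[nH]n2)cc1OC`, is not yet measured. Its change from compound 2 is hydrogen in place of methoxy on an aromatic carbon; it carries two methoxy groups where compound 2 carries three and compound 1 one. With compound 1 and compound 2 agreeing within the scatter, no step beyond the scatter is expected in either direction from compound 2 to compound 3, and the estimated step is a 1.0-fold lower number from compound 2 to compound 3 (0.02 log units; within the scatter). In this assay compound 3 is therefore expected near 6300 nM, with a range of 3000 nM to 13000 nM.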

Compound 3, concentration lethal to 50% of the cells: 7240 nM
Estimate against measurement, compound 3: 1.1-fold (0.06 log units) below, within the range that was stated.
By their numbers in this assay, from the lowest: compounds 1, 2 and 3 (each within the scatter of the next).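

In this assay the exchange of methoxy for hydrogen on the aromatic carbon ortho to a methoxy group and meta to a large group can now be read directly, as a 1.1-fold higher number from compound 2 to compound 3 (0.04 log units; within the scatter) and this methoxy group therefore leaves no trace beyond the scatter. The second single change, methoxy in place of hydrogen on an aromatic carbon, reads as a 1.2-fold higher number from compound 1 to compound 3 (0.07 log units; within the scatter) so each methoxy change can now be read on its own, which compound 1 and compound 2, differing in two places, did not allow. No accompanying measurement bears on what lies behind these steps.

Going by these compounds, all three compounds carry only methoxy or hydrogen at the changed positions, so it stays open whether a hydroxyl group, a fluorine atom or an amine there would move the number beyond the scatter. Also open, on these data alone, is whether the same picture holds when the amine of the shared core gives way to a carboxylic acid.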